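Working notes: methylsulfonyl to methylsulfamoyl in the series

A few compounds are considered here, and "the series" means these few. Any claim that something is new, unique, unknown or untested is made for them only; others in the source may bear on it.

Compound 1 `Cc1cnc(NC(=O)c2cc(Oc3cnc(C(=O)N(C)C)cn3)c3cc(C)oc3c2)cn1`: 176000 nM
Compound 2 `Cc1cnc(NC(=O)c2cc(Oc3cnc(C(=O)N(C)C)cn3)c3cc(C)nn3c2)cn1`: 123000 nM
Compound 3 `Cc1cnc(NC(=O)c2cc(Oc3ccc(S(C)(=O)=O)cc3)c3cn(C)nc3c2)cn1`: 454000 nM

These values come from a physicochemical assay for solubility, measured as kinetic solubility; a lower number here means a less soluble compound, a higher number a more soluble compound. Compound 3 stands highest of the three at 454000 nM, beyond the scatter from both compound 1 and compound 2. Compound 4 `CNS(=O)(=O)c1ccc(Oc2cc(C(=O)Nc3cnc(C)cn3)cc3nn(C)cc23)cc1` is not yet measured. It carries methylamino in place of methyl on a sulfonyl sulfur, which reads as methylsulfonyl to methylsulfamoyl. For the measured compounds named here, no measured pair shows this change, so the expectation is loose. Going by the values given here, with compound 3 at 454000 nM as the top number so far, a fall in this assay seems likelier than a rise. The expected change is a 1.9-fold lower number from compound 3 to compound 4 (0.28 log units; within the scatter), a small fall not clearly beyond the scatter. For compound 4 the estimate is 240000 nM, with an expected range of 90000 nM to 520000 nM.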

Compound 4, solubility: 27000 nM
Beside the measured number, compound 4's estimate is 8.9-fold (0.95 log units) above it; measured number below the stated range.
By their numbers in this assay, from the lowest: compound 4; then compounds 2 and 1 (each within the scatter of the next); then compound 3.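

In this assay, for the compounds shown here, methylamino in place of methyl on a sulfonyl sulfur gives a 17-fold lower number from compound 3 to compound 4 (1.23 log units; beyond the scatter), the first step that can be read as a single change. The group on this sulfonyl sulfur is therefore not a neutral place for change in this series: the swap, which adds one hydrogen-bond donor, moves the number well beyond the scatter. Nothing available bears on the reason for this fall.

On these data alone, whether the fall follows the nitrogen or its hydrogen stays open; dimethylamino on the same sulfur would separate the two. As far as these compounds go, how an unsubstituted amino group or a longer chain on that nitrogen would read also remains open.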